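The source may report more compounds than this note shows. Statements on the series, on what has been measured and on what is new or still open speak of the compounds shown alone.

Measured compounds:
- compound 1, `CCOC(=O)C1=C(C)NC(=S)NC1c1cn(C(=O)CNc2ccccc2Cl)c2ccccc12`: 3.44
- compound 2, `CCOC(=O)C1=C(C)NC(=O)NC1c1cn(C(=O)CNc2ccccc2N)c2ccccc12`: 0.74

In a physicochemical assay for lipophilicity (a lower number here means a more polar compound, a higher number a more lipophilic compound), compound 1 gives 3.44, the highest of the two numbers recorded. The nearest, compound 2, stands in this assay at 0.74, a gap beyond the scatter; compound 2 differs from compound 1 in more than one place, so the two values are merely set side by side.

Compound 3, `CCOC(=O)C1=C(C)NC(=S)NC1c1cn(C(=O)CNc2ccccc2N)c2ccccc12`, is not yet measured. Relative to compound 1 the change is amino in place of chloro on an aromatic carbon. For the measured compounds named here, no measured pair isolates this change. Compound 3 is expected to come out lower than compound 1 in this assay, by a step of a number 1.84 log units lower from compound 1 to compound 3 (beyond the scatter), clearly beyond the scatter. Compound 3 is estimated at 1.6, within a range from 0.9 to 2.4.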

Compound 3, partition coefficient: 2.14
For compound 3 the middle estimate is 0.54 log units below the measured one; low and high end bracket the measured number.
By their numbers in this assay, from the lowest: compound 2; then compound 3; then compound 1.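

In this assay, for the compounds shown here, amino in place of chloro on an aromatic carbon, ortho to a large group, gives a number 1.30 log units lower from compound 1 to compound 3 (beyond the scatter), the first reading of this change with the rest of the molecule unchanged. Compound 3 at 2.14 and compound 2 at 0.74 also differ in one place only, a thiocarbonyl against a carbonyl, so the gap between compound 1 and compound 2 no longer has to be read as one undivided difference. Nothing at hand bears on what lies behind the step.

The compounds shown carry only chloro and amino at this position, so the standing of a hydroxyl, a methoxy group or a carboxylic acid there in this assay remains open. From the compounds shown here alone, whether the step keeps its size with a carbonyl in place of the thiocarbonyl also remains open.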